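The source may hold more compounds than are shown below. What is called first, only, known or untested is meant among the compounds shown, and "the series" means these compounds.

Compound 1, `CCCCCNc1oc2c(C)ncc(CO)c2c1Nc1ccccn1`, is the starting point. In a functional assay on HEK293 cells for agonist activity at Toll-like receptor 8 (Homo sapiens), read by reporter gene assay (on this read-out lower numbers stand for an effect already at smaller amounts and higher numbers for an effect only at larger amounts of compound), compound 1 gives 5810 nM, which is the higher of the two numbers recorded in this series. Among the measured compounds shown here, compound 3, `CCCCCNc1oc2c(C)ncc(CO)c2c1Nc1ccccc1`, is its nearest neighbour: in this assay compound 3 gives 2250 nM, and the single change of a 2.6-fold lower number from compound 1 to compound 3 (0.41 log units; beyond the scatter). For the measured compounds named here, compound 2, `Cc1ncc(CO)c(-c2nc3ccccn3c2NC2CCCCC2)c1OCc1ccccc1`, carries a cyclohexyl group on an amino nitrogen but is built on a different core, and in this assay compound 2 is reported as "not active" (no number reported) without a number, so it offers no measured step.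

Compound 4, `Cc1ncc(CO)c2c(Nc3ccccn3)c(NC3CCCCC3)oc12`, differs from compound 1 at the other nitrogen on the shared core: cyclohexyl in place of pentyl on a nitrogen on an aromatic ring. Going by the values given here, no measured pair in this set makes this exchange of pentyl for cyclohexyl, so there is no step to rest on; the one step known, from compound 1 to compound 3, concerns a different position and a different kind of group. With nothing pointing in either direction, the expectation for compound 4 is a step of about a 1.2-fold lower number from compound 1 to compound 4 (0.07 log units; within the scatter), that is, a number close to that of compound 1 and within the usual scatter. Compound 4 is therefore estimated at 5000 nM, between 1500 nM and 16000 nM.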

Compound 4, half-maximal effective concentration: 6930 nM
Compound 4: middle estimate off by 1.4-fold (0.14 log units), on the low side, and the stated range covers the measured number.
By their numbers in this assay, from the lowest: compound 3; then compounds 1 and 4 (each within the scatter of the next).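

In this assay, the nitrogen carrying the pentyl group now has a measured step of its own: a 1.2-fold higher number from compound 1 to compound 4 (0.08 log units; within the scatter). The earlier step, from pyridin-2-yl to phenyl, concerned the other nitrogen and lay beyond the scatter, so it said nothing about this one. Here, an open five-carbon chain and a six-membered carbon ring give numbers that cannot be told apart, which shows that, on this core and with pyridin-2-yl on the other nitrogen, this exchange leaves the read-out unchanged within the scatter, and nothing available explains why the two groups read alike.

This is a single pair, so it does not show whether other groups at this nitrogen would also read the same, such as a shorter propyl chain, a longer heptyl chain, or a benzyl group. It also leaves open whether cyclohexyl behaves the same way with phenyl on the other nitrogen, as in compound 3, where the number is lower than that of compound 1 by more than the scatter.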